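This account rests on a few compounds, and the source may have more. Where it says the series, first, only, none or still open, it means among the compounds named here.

Measured so far in an assay on isolated protein for inhibition of DNA topoisomerase 1 (Homo sapiens), with a stated time of 30 min, tested at 100 uM; a lower number here means less inhibition, a higher number more inhibition at the concentration tested (going by the name of the read-out):
compound 1, `Cc1ccsc1-c1cc(-c2ccco2)cc(-c2ccccc2Cl)n1` — 2%
compound 2, `Cc1ccc(-c2cc(-c3ccoc3)cc(-c3ccc(Cl)s3)n2)o1` — 13.2%

Compound 2 stands highest of the two numbers measured. Its nearest neighbour is compound 1, whose inhibition lies lower by a gap that exceeds the usual scatter of this kind of measurement, so the two readings are distinguishable, though both remain modest at the concentration tested. Among the compounds with values here, the two compounds differ in more than one place, so no single structural step connects them, and the data allow only the statement that compound 2 inhibits more than compound 1 in this assay.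

Compound 3, `Cc1ccc(-c2cc(-c3ccoc3)cc(-c3ccc(Cl)s3)n2)cc1`, has not yet been measured. It differs from compound 2 in one place: 4-methylphenyl in place of 5-methylfuran-2-yl on an aromatic carbon. Within the data shown here, no step between measured compounds isolates a change of this kind, so the expectation rests on the weak inhibition seen for compound 2 alone. Compound 3 is expected to give 10%, in a range from 0% to 25%. The step of a number 3.2 percentage points lower from compound 2 to compound 3 (within the scatter) is expected to be small and not beyond the scatter, in either direction.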

Compound 3, a percentage reported as inhibition, at one concentration (the size of the read-out at that concentration, not a potency): 0%
For compound 3 the middle estimate is 10 percentage points above the measured one, within the range that was stated.
By their numbers in this assay, from the lowest: compounds 3 and 1 (each within the scatter of the next); then compound 2.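

In this assay, within the data shown here, the pair gives the first step that can be read at a single position: on the aromatic carbon next to the ring nitrogen, putting 4-methylphenyl in place of 5-methylfuran-2-yl gives a number 13.2 percentage points lower from compound 2 to compound 3 (beyond the scatter), a modest step. The 5-chlorothiophen-2-yl and furan-3-yl groups are the same in both compounds, so the step belongs to this one change, and this position is shown not to be indifferent to the ring it carries. The little inhibition seen for compound 2 is lost, with compound 3 giving 0% in this assay, and no measurement at hand accounts for the step.

The pair cannot separate the loss of the ring oxygen from the change to a six-membered ring of carbon only, as the two arrive together in this single swap. On these data alone, what a simple amine, a carboxylic acid or a longer alkyl chain on this carbon would give remains open, as does whether any group here could lift inhibition far above that of compound 2.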